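This account rests on a few compounds, and the source may have more. Where it says the series, first, only, none or still open, it means among the compounds named here.

Among the compounds with values here, in an ADME assay on MT4 cells (Homo sapiens) for cytotoxicity, read by MTT assay, with a stated time of 96 h (a lower number here means that less compound is tolerated, a higher number that more compound is tolerated), compound 3 (`NS(=O)(=O)c1ccc(N2N=C(c3ccc(Oc4ccccc4)cc3)CC2c2cccc(F)c2)cc1`) reads 25000 nM and this is the only actual number so far. Compound 1 (`Cc1ccccc1C1CC(c2ccc(OCc3ccccc3)cc2)=NN1c1ccc(S(N)(=O)=O)cc1`) gives >= 100000 nM and this is a limit of the assay, not a number. Compound 2 (`NS(=O)(=O)c1ccc(N2N=C(c3ccc(OCc4ccccc4)cc3)CC2c2ccccc2)cc1`) gives > 100000 nM and this is likewise a limit. Compound 3 therefore has no measured neighbour to be ranked against.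

The next compound is compound 4 (`NS(=O)(=O)c1ccc(N2N=C(c3ccc(Oc4ccccc4)cc3)CC2c2cccc(Cl)c2)cc1`), which differs from compound 3 by chloro in place of fluoro on an aromatic carbon, the change from 3-fluorophenyl to 3-chlorophenyl (chloro in place of fluoro on an aromatic carbon). The series holds a single measured step, a step that the two limits leave unreadable from compound 1 to compound 2 and its size cannot be carried over to the present change. Within the data shown here, no measured step covers a swap of fluoro for chloro. The expectation therefore rests on compound 3 at 25000 nM as the starting point and has no measured step size behind it.

The expected change is a 1.1-fold lower number from compound 3 to compound 4 (0.06 log units; within the scatter) and it is estimated to stay within the usual scatter, with no real direction claimed in this assay for now. A result reported only as a limit remains possible. For compound 4 the estimated value is 22000 nM with an expected range from 9000 nM to 55000 nM as a working figure.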

Compound 4, half-maximal cytotoxic concentration: 8000 nM
Compound 4: the middle estimate sits 2.8-fold (0.44 log units) above what was measured, outside the stated range (below it).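

Chloro in place of fluoro on this aromatic carbon, meta to a large group, gives a 3.1-fold lower number from compound 3 to compound 4 (0.49 log units; beyond the scatter) in this assay, so less compound is tolerated with 3-chlorophenyl than with 3-fluorophenyl, and the exchange of one halogen for another, with one heavy atom leaving, one entering and no donor or acceptor involved, is enough to move the read-out beyond the scatter. Within the data shown here, the earlier compounds could not show this: their only step cannot be read, and this is the first step with a readable size, resting on two actual numbers. No measured property in hand bears on what lies behind this step.

From the compounds shown here alone, with only fluoro and chloro compared at this place, it remains open whether the trend continues with bromo or reverses with a methoxy or an amine there, so no order of substituents can be drawn from one pair. Going by these compounds, it is also open whether the same swap would give a step of similar size on the core of compound 2, since one pair cannot show whether the step carries over to another core.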